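Quinolinone imines and hydrazones: weak inhibition throughout

The source may hold more compounds than are shown below. What is called first, only, known or untested is meant among the compounds shown, and "the series" means these compounds.

Measured compounds:
- compound 1 `O=c1[nH]c2ccccc2cc1/C=N/c1ccc(O)cc1` gives 306000 nM in a functional assay, read by spectrophotometry, with a stated time of 5 min; on this read-out higher numbers stand for weaker inhibition and lower numbers for stronger inhibition
- compound 2 `Cc1ccc2[nH]c(=O)c(/C=N/Nc3ccccc3)cc2c1` gives 309000 nM in this assay
- compound 3 `NS(=O)(=O)CC(=O)N/N=C/c1cc2ccccc2[nH]c1=O` gives 256000 nM in this assay

All three share the quinolinone core of compound 1 and differ only in the group on the imine nitrogen. Compound 2 stands alongside compounds 1 and 3: the three numbers lie within the usual scatter of one another, so no order can be read among them, and every variation tried so far at this position has left the read-out essentially unchanged.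

Compound 4 `Cc1ccc2[nH]c(=O)c(/C=N/Cc3ccccc3)cc2c1` is the next point. It differs from compound 2 by benzyl in place of anilino on a double-bonded nitrogen.

Nothing measured here links a change on the double-bonded nitrogen to any shift in this assay; the hydroxyphenyl of compound 1 and the sulfonamide-bearing chain of compound 3 sit at the same level as the anilino of compound 2. The expected step in this assay is therefore none beyond the scatter. The step this estimate implies is a 1.0-fold lower number from compound 2 to compound 4 (0.01 log units; within the scatter), expected to stay within the scatter. Compound 4 is expected at 300000 nM, with a range from 150000 nM to 600000 nM.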

Compound 4, half-maximal inhibitory concentration: 310000 nM
Compound 4: middle estimate off by 1.0-fold (0.01 log units), on the low side; measured number inside the range.
By their numbers in this assay, from the lowest: compounds 3, 1, 2 and 4 (each within the scatter of the next).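

For the compounds shown here, compound 2 and compound 4 are the first pair that differs in one place, and in this assay benzyl in place of anilino on a double-bonded nitrogen gives a 1.0-fold higher number from compound 2 to compound 4 (0.00 log units; within the scatter) and so no readable shift. The anilino carries 1 hydrogen-bond donor and 1 hydrogen-bond acceptor and the benzyl carries 0 of each, yet this difference in counts comes with no separation between the two numbers. No measurement is available that bears on why the two compounds sit level.

Open, going by these compounds, is whether a carboxylic acid or an amine at the end of a longer chain on this nitrogen would move the number beyond the scatter. Also open, on these data alone, is whether a fluorine or a methoxy group on the benzyl ring would do so.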